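This account rests on a few compounds, and the source may have more. Where it says the series, first, only, none or still open, it means among the compounds named here.

The measured compounds, one per line:

In a functional assay on HT-29 cells (Homo sapiens) for inhibition, read by MTT assay, with a stated time of 72 h (on this read-out higher numbers stand for weaker inhibition of growth and lower numbers for stronger inhibition of growth), compound 1 `CC(C)(C)c1ccc(CNCCCNS(=O)(=O)c2cc(C(F)(F)F)cc(C(F)(F)F)c2)cc1` gives 2000 nM.
In this assay compound 2 `O=S(=O)(NCCCNCc1ccc(Cl)c(Cl)c1)c1cc(C(F)(F)F)cc(C(F)(F)F)c1` gives 4700 nM.
Compound 3 `CN(CCCNS(=O)(=O)c1cc(C(F)(F)F)cc(C(F)(F)F)c1)Cc1ccccc1` gives only a limit of the assay, > 50000 nM.

As far as these compounds go, compound 3 thus stands at the edge of what this assay reports, as the limit of > 50000 nM in this assay, at which 1 of the 3 values shown sits, shows, so its true number is unknown. Compound 4 `COc1cccc(CNCCCNS(=O)(=O)c2cc(C(F)(F)F)cc(C(F)(F)F)c2)c1` differs from it in one place: (3-methoxybenzyl)amino in place of benzyl(methyl)amino on a saturated chain carbon, three bonds along the chain from a sulfonamide nitrogen. For the measured compounds named here, two measured steps bear on this. The step of an at least 10-fold higher number from compound 2 to compound 3 (1.02 log units; beyond the scatter) was large, and it removed the secondary amine and the 3,4-dichlorophenyl at the same time; the step of a 2.4-fold higher number from compound 1 to compound 2 (0.37 log units; beyond the scatter) was modest, showing that swapping one substituted benzyl for another moves the number only a little. Compound 4 carries a secondary amine again, like compounds 1 and 2, with a 3-methoxybenzyl group in place of their substituted benzyls. A good part of the loss seen from compound 2 to compound 3 is therefore expected to be reversed, and the expected step is an at least 6.2-fold lower number from compound 3 to compound 4 (0.79 log units; beyond the scatter). Compound 4 is expected to give about 8000 nM in this assay, within a range from 2500 nM to 30000 nM.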

Compound 4, concentration for 50% growth inhibition: 10000 nM
Beside the measured number, compound 4's estimate is 1.3-fold (0.10 log units) below it, within the range that was stated.
By their numbers in this assay, from the lowest: compound 1; then compound 2; then compound 4. At a limit, above all of these: compound 3.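

In this assay, the step of an at least 5.0-fold lower number from compound 3 to compound 4 (0.69 log units; beyond the scatter) shows that a secondary amine carrying a 3-methoxybenzyl group gives a number inside the assay's range, unlike the benzyl(methyl)amino of compound 3. Compound 3 itself stands only at a limit of the assay, so that step is a bound: the limit of > 50000 nM in this assay, at which 1 of the 4 values shown sits. Among the secondary amines the aryl group still moves the number, with a 2.1-fold higher number from compound 2 to compound 4 (0.33 log units; beyond the scatter) and a 5.0-fold higher number from compound 1 to compound 4 (0.70 log units; beyond the scatter) placing 3-methoxyphenyl behind both 3,4-dichlorophenyl and 4-(tert-butyl)phenyl here.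

The compounds shown do not separate the methyl on the amine nitrogen from the change of ring substituent as the source of the gap at compound 3. Also open, as far as these compounds go, is how an amide in place of the amine, or a longer chain between the two nitrogens, would read in this assay.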